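The source may hold more compounds than are shown below. What is called first, only, known or untested is meant among the compounds shown, and "the series" means these compounds.

Measured so far in a functional assay on A549 cells (Homo sapiens) for antiproliferative activity, read by MTT assay; on this read-out lower numbers stand for stronger inhibition and higher numbers for weaker inhibition:
- compound 1 `Cn1c(=O)c(=O)n(C2CCCC2)c2nc(N/N=C/c3ccc(C(F)(F)F)cc3)ncc21`: 40600 nM
- compound 2 `Cn1c(=O)c(=O)n(C2CCCC2)c2nc(N/N=C/c3cccc(O)c3)ncc21`: > 100000 nM

Compound 2 gives only a limit, not a number, and stands at the limit of > 100000 nM in this assay, at which 1 of the 2 values shown sits. Compound 3 `Cn1c(=O)c(=O)n(C2CCCC2)c2nc(N/N=C/c3ccccc3F)ncc21` differs from it as follows: 2-fluorophenyl in place of 3-hydroxyphenyl on a carbon with a double bond to nitrogen. For the measured compounds named here, one measured step bears on this change, an at least 2.4-fold higher number from compound 1 to compound 2 (0.39 log units; beyond the scatter), which is at least modest and brought in the 3-hydroxyphenyl that compound 3 gives up. A modest step towards a lower number, meaning stronger inhibition, is therefore expected in this assay. The fit is loose. The entering group differs from that of compound 1. The expected step is an at least 1.6-fold lower number from compound 2 to compound 3 (0.22 log units; that floor lies within the scatter). For compound 3 the estimate is 60000 nM, with an expected range of 25000 nM to 100000 nM.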

Compound 3, half-maximal inhibitory concentration: 31200 nM
Estimate against measurement, compound 3: 1.9-fold (0.28 log units) above; the measured number falls inside the stated range.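

In this assay, 2-fluorophenyl in place of 3-hydroxyphenyl on the carbon with a double bond to nitrogen gives an at least 3.2-fold lower number from compound 2 to compound 3 (0.50 log units; beyond the scatter). This step is a bound and not a size, since compound 2 gives only a limit: the limit of > 100000 nM in this assay, at which 1 of the 3 values shown sits. Against the 4-(trifluoromethyl)phenyl group, the same 2-fluorophenyl gives a 1.3-fold lower number from compound 1 to compound 3 (0.11 log units; within the scatter), so these two groups are not told apart here.

On these data alone, whether the step follows from the fluorine entering or the hydroxyl leaving stays open. So does how a phenyl bearing an amine or a carboxylic acid would read.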